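This account rests on a few compounds, and the source may have more. Where it says the series, first, only, none or still open, it means among the compounds named here.

Of the compounds shown here, two have numbers so far. In an ADME assay on MT4 cells (Homo sapiens) for cytotoxicity, read by XTT assay, with a stated time of 5 days (a lower number here means that less compound is tolerated, a higher number that more compound is tolerated), compound 1 (`C=CCNC(=O)[C@@H](NC(=O)[C@](O)(CCCN(Cc1ccc(Br)cc1)NC(=O)[C@@H](NC(=O)OC)C(C)(C)C)Cc1ccc(Br)cc1)C(C)C`) gives 4500 nM and compound 2 (`C=CCNC(=O)[C@@H](NC(=O)[C@@](O)(CCCN(Cc1ccc(Br)cc1)NC(=O)[C@@H](NC(=O)OC)C(C)(C)C)Cc1ccc(C=C)cc1)C(C)C`) gives 25000 nM as the higher of the two, a gap beyond the scatter. Compound 3 (`C=CCNC(=O)[C@@H](NC(=O)[C@](O)(CCCN(Cc1ccc(Br)cc1)NC(=O)[C@@H](NC(=O)OC)C(C)(C)C)Cc1ccc(C=C)cc1)C(C)C`) differs from compound 2 only in configuration (the two compounds have the same atoms and bonds and differ only in configuration as drawn: 1 of 3 stereo elements differ; a stereocentre at a saturated chain carbon is drawn R in compound 2 and S in compound 3), with a stereocentre at a saturated chain carbon drawn R in compound 2 and S in compound 3. Within the data shown here, no measured step shows what such a change does in this assay here, so at most a modest move to a lower number is expected, hardly beyond the scatter. The estimate means a 1.6-fold lower number from compound 2 to compound 3 (0.19 log units; within the scatter) as the expected step. Compound 3 is expected at 16000 nM with an estimated range from 5500 nM to 42000 nM for the coming measurement.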

Compound 3, half-maximal cytotoxic concentration: 5800 nM
The estimate for compound 3 lay 2.8-fold (0.44 log units) above the measured number; measured number inside the range.
By their numbers in this assay, from the lowest: compounds 1 and 3 (each within the scatter of the next); then compound 2.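

In this assay, redrawing a single stereocentre at a saturated chain carbon gives a 4.3-fold lower number from compound 2 to compound 3 (0.63 log units; beyond the scatter), so this position responds to configuration alone. That step can be put down to the stereocentre because of one structural fact: the fact that compounds 2 and 3 differ only in the configuration as drawn By contrast, vinyl in place of bromo on an aromatic carbon gives a 1.3-fold higher number from compound 1 to compound 3 (0.11 log units; within the scatter).

On these data alone, whether the same configurational gap holds with bromo at that aromatic carbon remains open. So does the outcome for an ethyl or a methoxy group there, under either configuration.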